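This account rests on a few compounds, and the source may have more. Where it says the series, first, only, none or still open, it means among the compounds named here.

The series is followed in a toxicity assay on THP-1 cells (Homo sapiens) for inhibition; a higher number here means that more compound is tolerated, a lower number that less compound is tolerated. Compound 1 `Cn1c(-c2cccc([N+](=O)[O-])c2)cnc1NC(=O)c1ccc(F)cc1` carries a nitro group on its pendant aryl; in this assay compound 1 reaches only the limit > 50000 nM, not a number. Compound 2 `Cn1c(-c2cccc(C#N)c2)cnc1NC(=O)c1ccc(F)cc1` likewise gives only the limit > 100000 nM. Among the measured compounds shown here, the single step between measured compounds that differ in one place, a step that the two limits leave unreadable from compound 1 to compound 2, is therefore not readable as a number. Compound 3 `COc1ccc(-c2cnc(NC(=O)c3ccccc3F)n2C)cc1` also stands at a limit, giving > 100000 nM in this assay. For the measured compounds named here, two of the three values sit at the limit of > 100000 nM in this assay, at which 2 of the 3 values shown sit, and the remaining one at the limit of > 50000 nM in this assay, at which 1 of the 3 values shown sits, so no measured step has a readable size. Compound 4 `COc1ccc(-c2cnc(NC(=O)c3cccc(OC)c3)n2C)cc1` differs from compound 3 by 3-methoxyphenyl in place of 2-fluorophenyl on a carbonyl carbon. No measured step touches the group on the carbonyl carbon, so nothing shown bears directly on this change, and with every value at a limit no direction can be drawn from the series. The expected step is a step that the limit leaves unreadable from compound 3 to compound 4, none beyond the scatter, with a limit again the most likely outcome. Compound 4 is expected at 120000 nM in this assay, with a range from 40000 nM to 300000 nM.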

Compound 4, half-maximal cytotoxic concentration: > 100000 nM
Compound 4: no number, only a limit; the forecaster's own chance of this, stated with the estimate: 85%; the middle value lies beyond the limit too.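

In this assay compound 4 gives > 100000 nM, a limit and not a number. Compound 3 also stands at a limit, so the step between compound 3 and compound 4 cannot be read. The compounds shown leave open whether 3-methoxyphenyl in place of 2-fluorophenyl on a carbonyl carbon changes the half-maximal cytotoxic concentration at all.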